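A few compounds are considered here, and "the series" means these few. Any claim that something is new, unique, unknown or untested is made for them only; others in the source may bear on it.

Measured so far:
- compound 1, `Cc1cccc(N2CCC(C(=O)Nc3ccc4c(c3)NC(=O)CO4)CC2)c1`: 490 nM
- compound 2, `O=C1COc2ccc(NC(=O)C3CCN(c4cc(F)c(F)c(F)c4)CC3)cc2N1`: 59 nM

Both compounds share one core and differ only in the aryl group on the amine nitrogen of the six-membered ring. In a functional assay for antagonist activity at transient receptor potential cation channel subfamily V member 1 (Homo sapiens), read by FLIPR and calcium flux (a lower number here means a stronger inhibitor, a higher number a weaker inhibitor), compound 2 gives the lowest of the two numbers; its nearest neighbour is compound 1, and the step of an 8.3-fold lower number from compound 1 to compound 2 (0.92 log units; beyond the scatter) lies beyond the scatter.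

Compound 3, `Cc1cccc(N2CCC(C(=O)Nc3ccc4c(c3)NC(=O)CO4)CC2)c1C`, has not been measured. It differs from compound 2 by 2,3-dimethylphenyl in place of 3,4,5-trifluorophenyl on an amine nitrogen in a ring. Going by the values given here, the only measured step that bears on this change is the one from compound 1 to compound 2, where a methyl-bearing phenyl gave way to the trifluorophenyl and the number fell by an 8.3-fold lower number from compound 1 to compound 2 (0.92 log units; beyond the scatter). Compound 3 reverses that direction: the trifluorophenyl leaves and a methyl-bearing phenyl, here 2,3-dimethylphenyl, enters. Among the compounds with values here, no measured pair shows what the second methyl adds, so the expectation rests on the single step alone. A step of roughly the same size in the opposite direction is expected, that is a higher number for compound 3 in this assay, a 6.8-fold higher number from compound 2 to compound 3 (0.83 log units; beyond the scatter). Compound 3 is therefore estimated at 400 nM, within 120 nM to 1500 nM.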

Compound 3, half-maximal inhibitory concentration: 60 nM
Compound 3: middle estimate off by 6.7-fold (0.82 log units), on the high side; measured number outside the range, below it.
By their numbers in this assay, from the lowest: compounds 2 and 3 (each within the scatter of the next); then compound 1.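

In this assay, the aryl group on the amine nitrogen in a ring can be the carbon-only 2,3-dimethylphenyl as well as 3,4,5-trifluorophenyl, with a 1.0-fold higher number from compound 2 to compound 3 (0.01 log units; within the scatter), so fluorine on this phenyl is not required for a number of this size among these compounds. The earlier step alone could not show this: a single methyl in place of hydrogen on an aromatic carbon gives an 8.2-fold lower number from compound 1 to compound 3 (0.91 log units; beyond the scatter), a change comparable in size to an 8.3-fold lower number from compound 1 to compound 2 (0.92 log units; beyond the scatter), although the two changes have no atom type in common. No measurement on hand explains why these two different aryl groups give matching numbers.

On these data alone, what remains open is whether the gain from the added methyl depends on methyl itself or would also follow from a chlorine, a methoxy group or a trifluoromethyl group on the same aromatic carbon. Also open, as far as these compounds go, is whether methyl and fluorine together on one phenyl would lower the number further or leave it unchanged.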